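The source may hold more compounds than are shown below. What is called first, only, known or untested is meant among the compounds shown, and "the series" means these compounds.

Compound 1 `CN(CCCCON)C[C@H]1O[C@@H](n2cnc3c(N)ncnc32)[C@H](O)[C@@H]1O` is the starting point, and in an assay on isolated protein for inhibition of S-adenosylmethionine decarboxylase proenzyme (Homo sapiens) (a higher number here means a weaker inhibitor, a lower number a stronger inhibitor), compound 1 gives 18 nM, the highest of the three numbers. Compound 2 `Cc1nc2c(N)ncnc2n1[C@@H]1O[C@H](CN(C)CCCCON)[C@@H](O)[C@H]1O` gives 5 nM in this assay, and compound 3 `CN(CCCCON)C[C@H]1O[C@@H](n2c(O)nc3c(N)ncnc32)[C@H](O)[C@@H]1O` gives 11 nM. The steps of a 3.6-fold lower number from compound 1 to compound 2 (0.56 log units; beyond the scatter) and a 1.6-fold lower number from compound 1 to compound 3 (0.21 log units; within the scatter) both alter only the aromatic part of the shared core. Compound 4 `C[S+](C)C[C@H]1O[C@@H](n2cnc3c(N)ncnc32)[C@H](O)[C@@H]1O` changes something else: a group of 3 heavy atoms (2 carbon, 1 sulfur; no ring) in place of a group of 8 heavy atoms (5 carbon, 2 nitrogen, 1 oxygen; no ring), on a saturated chain carbon bound to a saturated ring carbon. For the measured compounds named here, no measured step touches this chain, so the earlier steps offer no direct guide, and the chain that leaves is the part carrying the hydrogen-bond donor. A large loss is therefore expected, a 170-fold higher number from compound 1 to compound 4 (2.22 log units; beyond the scatter). The estimate for compound 4 in this assay is 3000 nM, expected within 300 nM to 30000 nM.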

Compound 4, half-maximal inhibitory concentration: 5000 nM
The estimate for compound 4 lay 1.7-fold (0.22 log units) below the measured number; the range from low to high includes it.
By their numbers in this assay, from the lowest: compound 2; then compounds 3 and 1 (each within the scatter of the next); then compound 4.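

The earlier steps shown here altered only the aromatic part of the shared core and were modest or within the scatter. This first change on the saturated chain carbon bound to a saturated ring carbon has a much larger effect in this assay, with a 280-fold higher number from compound 1 to compound 4 (2.44 log units; beyond the scatter). Nothing available shows whether losing the chain or gaining the net charge +1 matters more.

An amine or a longer chain at this place could separate these two changes. From the compounds shown here alone, whether the aromatic methyl of compound 2 would lower the number with the smaller group also remains open.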